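The source may report more compounds than this note shows. Statements on the series, on what has been measured and on what is new or still open speak of the compounds shown alone.

Measured in an assay on membranes from brain for displacement of a labelled ligand from Neuronal acetylcholine receptor; alpha4/beta2 (Rattus norvegicus), with a stated time of 3 h; a lower number here means a stronger inhibitor, a higher number a weaker inhibitor:
compound 1 `CC(C)(C)C(=O)Oc1ccccc1/C=C1\CCCN=C1c1cccnc1` — 1440 nM
compound 2 `N#Cc1ccc(/C=C2\CCCN=C2c2cccnc2)cc1` — 1230 nM
compound 3 `CC(C)(C)C(=O)Oc1ccc(/C=C2\CCCN=C2c2cccnc2)cc1` — 830 nM

Compound 3 gives the lowest of the three numbers in this assay, but its gaps to compound 2 and to compound 1 are both within the scatter, so the three compounds are not separated. For the measured compounds named here, the only single-place step is a 1.5-fold lower number from compound 2 to compound 3 (0.17 log units; within the scatter), also within the scatter.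

Compound 4 `C(=C1\CCCN=C1c1cccnc1)\c1ccccc1` differs from compound 3 by hydrogen in place of ((tert-butyl)carbonyl)oxy on an aromatic carbon. Going by the values given here, no measured step removes a group from that aromatic carbon altogether; the one step on it, a 1.5-fold lower number from compound 2 to compound 3 (0.17 log units; within the scatter), shows that exchanging one group for another there leaves the number unchanged within the scatter. As far as these compounds go, no step beyond the scatter is therefore expected for compound 4, though the range is kept wide since the change is untested.

Compound 4 is estimated at 1200 nM, within 400 nM to 3600 nM. The expected step is a 1.4-fold higher number from compound 3 to compound 4 (0.16 log units; within the scatter).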

Compound 4, inhibition constant: 850 nM
Beside the measured number, compound 4's estimate is 1.4-fold (0.15 log units) above it, within the range that was stated.
By their numbers in this assay, from the lowest: compounds 3, 4, 2 and 1 (each within the scatter of the next).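

In this assay, hydrogen in place of ((tert-butyl)carbonyl)oxy gives a 1.0-fold higher number from compound 3 to compound 4 (0.01 log units; within the scatter), so taking this group off the aromatic carbon altogether, not only exchanging it, leaves the number unchanged within the scatter. The other two steps to the unsubstituted compound agree: hydrogen in place of cyano gives a 1.4-fold lower number from compound 2 to compound 4 (0.16 log units; within the scatter), and hydrogen in place of ((tert-butyl)carbonyl)oxy on compound 1 gives a 1.7-fold lower number from compound 1 to compound 4 (0.23 log units; within the scatter). No measurement at hand accounts for this flat result. As far as these compounds go, whether an amine or a carboxylic acid on this aromatic carbon would give a step beyond the scatter remains open.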